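This account rests on a few compounds, and the source may have more. Where it says the series, first, only, none or still open, it means among the compounds named here.

Series notes. Three compounds share a core and vary the group on an amine nitrogen in a ring: compound 1 `Nc1scc(CN2CCN(c3ccc(Cl)cc3Cl)CC2)c1C(=O)c1ccc(Cl)cc1`, compound 2 `COc1ccc(N2CCN(Cc3csc(N)c3C(=O)c3ccc(Cl)cc3)CC2)cc1` and compound 3 `Nc1scc(CN2CCN(c3ccc([N+](=O)[O-])cc3)CC2)c1C(=O)c1ccc(Cl)cc1`. In an assay on CHO cells for displacement of a labelled ligand from adenosine receptor A3 (Homo sapiens), read by scintillation counting, with a stated time of 120 min, tested at 10 uM (on this read-out lower numbers stand for less inhibition and higher numbers for more inhibition at the one concentration tested (going by the name of the read-out)), compound 1 gives 0%, compound 2 gives 0% and compound 3 gives 2%. The steps among them are small: no change at the digits printed from compound 1 to compound 2 (within the scatter), a number 2 percentage points higher from compound 1 to compound 3 (within the scatter) and a number 2 percentage points higher from compound 2 to compound 3 (within the scatter). Compound 2 thus stands level with compound 1 at the digits printed, the two together the lowest of the three numbers, with compound 3 the furthest away and still within the scatter.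

Compound 4 `Nc1scc(CN2CCN(CCCc3ccc(Cl)cc3)CC2)c1C(=O)c1ccc(Cl)cc1` is the next member, not yet measured in this assay. It differs from compound 2 as follows: 3-(4-chlorophenyl)propyl in place of 4-methoxyphenyl on an amine nitrogen in a ring. Among the measured compounds shown here, none of the measured steps covers this kind of change; each of them exchanges one aryl group for another on that nitrogen and none moves the read-out beyond the scatter. For the measured compounds named here, nothing so far points toward a gain in this assay, so the step is expected to be a number 2 percentage points higher from compound 2 to compound 4 (within the scatter), none beyond the scatter. For compound 4 the expected value in this assay is 2%, in a range from -8% to 14%.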

Compound 4, a percentage reported as inhibition, at one concentration (the size of the read-out at that concentration, not a potency): 0%
Compound 4: middle estimate off by 2 percentage points, on the high side, and the stated range covers the measured number.
By their numbers in this assay, from the lowest: compounds 1, 2, 4 and 3 (each within the scatter of the next).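

In this assay this position on the amine nitrogen in the ring now carries an aromatic ring held on a propyl chain rather than attached directly, and the read-out gives no change at the digits printed from compound 2 to compound 4 (within the scatter) and a number 2 percentage points lower from compound 3 to compound 4 (within the scatter) and no change at the digits printed from compound 1 to compound 4 (within the scatter) as the three steps to the new member. The change of attachment therefore adds something the aryl-for-aryl exchanges could not test: this larger change at the same nitrogen, which also swaps the oxygen of 4-methoxyphenyl for the chlorine of 3-(4-chlorophenyl)propyl, still leaves all four compounds within the scatter of one another at the one concentration tested. No measurement here bears on why the read-out stays where it does.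

Open, on these data alone, is whether another kind of group on this nitrogen, such as a benzyl group, an acyl group or a longer chain ending in a carboxylic acid, would move the number beyond the scatter. Also open, as far as these compounds go, is whether any change away from this nitrogen, for example an amide in place of the free amine on the shared core, would give a read-out that differs from these four.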